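Aryl ether variation in the imine-linked series

The compounds below may be only part of what the source reports. "The series", "measured", "known", "first", "only" and "open" are said of these compounds alone.

Two compounds of the series carry numbers in a functional assay on HepG2 cells (Homo sapiens) for antiproliferative activity, read by MTT assay, with a stated time of 72 h; on this read-out higher numbers stand for weaker inhibition and lower numbers for stronger inhibition. Compound 1 `Cc1nn(C)c(Oc2ccc(Cl)cc2)c1/C=N\CCCCCOc1cc2oc(=O)cc(C)c2cc1Cl` gives 15300 nM in this assay. Compound 2 `Cc1nn(C)c(Oc2cccc(F)c2F)c1/C=N\CCCCCCOc1cc2oc(=O)cc(C)c2cc1Cl` reaches only a limit of this assay, reported as > 25000 nM. That value is the limit of > 25000 nM in this assay, at which 1 of the 2 values shown sits, so the place of compound 2 on the scale is known only as a bound, not a number. Among the compounds with values here, no step between measured compounds is available, since compound 1 and compound 2 differ in more than one place; what their two values show is that compound 1 has a number while compound 2 has a limit. Compound 3 `Cc1nn(C)c(Oc2ccc(Br)cc2)c1/C=N\CCCCCCOc1cc2oc(=O)cc(C)c2cc1Cl` is not yet measured. It differs from compound 2 by 4-bromophenyl in place of 2,3-difluorophenyl on an oxygen on an aromatic ring. Compound 1, which also carries a single halogen on that phenyl, gives 15300 nM, and that is the only ground for the expectation below. In this assay a modest step, towards stronger inhibition if anywhere, is expected: an at least 1.3-fold lower number from compound 2 to compound 3 (0.14 log units; that floor lies within the scatter). Compound 3 is expected to give about 18000 nM in this assay, with a range from 8000 nM to 40000 nM, and a real chance that only a limit is again reported.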

Compound 3, half-maximal inhibitory concentration: 4630 nM
Estimate against measurement, compound 3: 3.9-fold (0.59 log units) above; measured number outside the range, below it.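

Notes on the aryl ether position: compounds 2 and 3 are the first pair in the series that differ in one place, so the effect of the group on this oxygen can be read with the rest of the structure held constant. In this assay, 4-bromophenyl in place of 2,3-difluorophenyl gives an at least 5.3-fold lower number from compound 2 to compound 3 (0.73 log units; beyond the scatter), which shows that this position alone can move the read-out beyond the scatter. Compound 2 stands at a limit, not at a number, so the step has only a floor and its full size stays unknown: the limit of > 25000 nM in this assay, at which 1 of the 3 values shown sits.

The change removes two fluorines and brings in one bromine on the phenyl at the same time, so the compounds shown do not separate the gain of bromine from the loss of fluorine, or the identity of a halogen from where it sits on the ring. Also open, on these data alone, is whether a halogen is needed at all, since a phenyl carrying a methoxy group or an amine would test the position with a different kind of substituent.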